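A few compounds are considered here, and "the series" means these few. Any claim that something is new, unique, unknown or untested is made for them only; others in the source may bear on it.

Measured compounds:
Compound 1 `NC(=O)[C@H](CO)Nc1cc(=O)oc2cc(OCc3cccc(Cl)c3)ccc12` in an assay (strain Wistar) for inhibition of Amine oxidase [flavin-containing] A (Rattus norvegicus) (on this read-out lower numbers stand for stronger inhibition and higher numbers for weaker inhibition), gives > 100000 nM, which is a limit of the assay and not a number.
Compound 2 `CN(Cc1ccccc1)Cc1cc(=O)oc2cc(OCc3cccc(Cl)c3)ccc12` in this assay gives > 100000 nM, again a limit and not a number.
Compound 3 `NCc1cc(=O)oc2cc(OCc3ccccc3)ccc12` in this assay gives 4400 nM.

Among the measured compounds shown here, compound 3 therefore holds the only number in the set; the other two entries are limits, as the limit of > 100000 nM in this assay, at which 2 of the 3 values shown sit, states. Compound 4 `NCc1cc(=O)oc2cc(OCc3cccc(Cl)c3)ccc12` differs from compound 3 by chloro in place of hydrogen on an aromatic carbon, placed on an aromatic carbon of a six-membered aromatic ring of carbon only, meta to a large group. For the measured compounds named here, the single measured step, a step that the two limits leave unreadable from compound 1 to compound 2, runs between two limits and has no readable size, and it concerns the other substituent on the shared core rather than the chloro. Going by the values given here, no measured step bears on the chloro change itself. Compounds 1 and 2 carry the chloro and sit at the limit, while compound 3 lacks it and gives a number, but their other groups differ as well, so these values show only that much. For compound 4 a step within the scatter is expected, a 1.3-fold lower number from compound 3 to compound 4 (0.10 log units; within the scatter), and the estimate for compound 4 in this assay is 3500 nM, with a range from 1000 nM to 15000 nM.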

Compound 4, half-maximal inhibitory concentration: 2000 nM
For compound 4 the middle estimate is 1.8-fold (0.24 log units) above the measured one; measured number inside the range.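

In this assay, the change from phenyl to 3-chlorophenyl now has a readable size, a 2.2-fold lower number from compound 3 to compound 4 (0.34 log units; beyond the scatter), so chloro on this aromatic carbon gives a modest gain with the aminomethyl group in place. With the 3-chlorophenyl held in common, the other substituent on the shared core makes much larger steps: amino replacing benzyl(methyl)amino on the saturated chain carbon gives an at least 50-fold lower number from compound 2 to compound 4 (1.69 log units; beyond the scatter), and aminomethyl replacing (1-carbamoyl-2-hydroxyethyl)amino gives an at least 50-fold lower number from compound 1 to compound 4 (1.69 log units; beyond the scatter). The sizes of these two larger steps start from limits of the assay and not from numbers: the limit of > 100000 nM in this assay, at which 2 of the 4 values shown sit.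

Going by these compounds, whether fluoro, bromo or methoxy in place of this chloro would give a different number stays open. So does the effect of replacing aminomethyl with methylaminomethyl or a longer aminoethyl chain.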